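Sulfamoyl for Acetamido: What to Expect of Compound 4

The source may hold more compounds than are shown below. What is called first, only, known or untested is meant among the compounds shown, and "the series" means these compounds.

Of the compounds shown here, three sharing one core have been measured in a functional assay for inhibition, with Homo sapiens as the target; a higher number here means a weaker inhibitor, a lower number a stronger inhibitor. Compound 1 `CC1CCN(c2ccc(Nc3nccc(-c4cccnc4)n3)cc2)CC1` gives 500 nM. Compound 2 `CNc1ccc(Nc2nccc(-c3cccnc3)n2)cc1` gives 2100 nM, and compound 3 `CC(=O)Nc1ccc(Nc2nccc(-c3cccnc3)n2)cc1` gives 3600 nM. Compound 3 thus carries the highest number of the three, though its distance to compound 2 stays within the scatter; compound 1 lies furthest from it. The steps leading to it were a 4.2-fold higher number from compound 1 to compound 2 (0.62 log units; beyond the scatter), a 7.2-fold higher number from compound 1 to compound 3 (0.86 log units; beyond the scatter) and a 1.7-fold higher number from compound 2 to compound 3 (0.23 log units; within the scatter).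

Compound 4 `NS(=O)(=O)c1ccc(Nc2nccc(-c3cccnc3)n2)cc1` differs from compound 3 in one place: sulfamoyl in place of acetamido on an aromatic carbon. Going by the values given here, no measured step involves a sulfamoyl, so the closest guides are the two exchanges at the same aromatic carbon, which moved the number only modestly, and the exchange of acetyl for methyl, which stayed within the scatter. A change of at most modest size is therefore expected in this assay, with no clear direction. Compound 4 is expected to give 4000 nM, within a range from 1500 nM to 12000 nM. That estimate means an expected step of a 1.1-fold higher number from compound 3 to compound 4 (0.05 log units; within the scatter).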

Compound 4, half-maximal inhibitory concentration: 200 nM
Compound 4: middle estimate off by 20-fold (1.30 log units), on the high side; measured number outside the range, below it.
By their numbers in this assay, from the lowest: compound 4; then compound 1; then compounds 2 and 3 (each within the scatter of the next).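

In this assay, going by these compounds alone, the aromatic carbon para to a large group proves far more responsive than the earlier compounds showed: sulfamoyl in place of acetamido gives an 18-fold lower number from compound 3 to compound 4 (1.26 log units; beyond the scatter) and in place of methylamino gives an 11-fold lower number from compound 2 to compound 4 (1.02 log units; beyond the scatter), both large where the earlier exchanges were at most modest. Sulfamoyl, the only group here attached through sulfur rather than nitrogen, also gives a 2.5-fold lower number from compound 1 to compound 4 (0.40 log units; beyond the scatter) when it takes the place of 4-methylpiperidin-1-yl, so the lowest number no longer belongs to compound 1. Nothing available here accounts for the gain.

As far as these compounds go, whether a methylsulfonyl group or a carboxylic acid at this carbon would give a similarly low number remains open. So does whether the same exchange would hold on a different core.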